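Ring expansion on a sulfonyl group and liver-cell toxicity

This account rests on a few compounds, and the source may have more. Where it says the series, first, only, none or still open, it means among the compounds named here.

Compound 1 `CN1CCN(S(=O)(=O)c2ccc(-c3ccc4c(Nc5ccc(OCc6cccc(F)c6)c(Cl)c5)nccc4c3)cc2)CC1` was tested in a toxicity assay on HepG2 cells (Homo sapiens) for cytotoxicity, read by MTT assay, with a stated time of 48 h; on this read-out higher numbers stand for lower toxicity in this test and lower numbers for higher toxicity in this test. In this assay compound 1 gives only a limit, > 15 uM. Compound 2 `CN1CCCN(S(=O)(=O)c2ccc(-c3ccc4c(Nc5ccc(OCc6cccc(F)c6)c(Cl)c5)nccc4c3)cc2)CC1` carries 4-methyl-1,4-diazepan-1-yl in place of 4-methylpiperazin-1-yl on a sulfonyl sulfur. In this assay compound 2 likewise gives only a limit, > 15 uM. The measured step is thus a step that the two limits leave unreadable from compound 1 to compound 2. Compound 3 `CN1CCN(S(=O)(=O)c2ccc(-c3ccc4c(Nc5ccc(OCc6cccc(F)c6)c(Cl)c5)cnnc4c3)cc2)CC1` has another core; the difference between the two cores is not broken down here. In this assay compound 3 also gives only a limit, > 15 uM. What the three values share is the limit of > 15 uM in this assay, at which 3 of the 3 values shown sit, so none of them is a number.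

Compound 4 `CN1CCCN(S(=O)(=O)c2ccc(-c3ccc4c(Nc5ccc(OCc6cccc(F)c6)c(Cl)c5)cnnc4c3)cc2)CC1` has not yet been measured. Going by the values given here, it differs from compound 3 by 4-methyl-1,4-diazepan-1-yl in place of 4-methylpiperazin-1-yl on a sulfonyl sulfur, the same change at the same place as the one from compound 1 to compound 2. The step that the limit leaves unreadable from compound 3 to compound 4 is expected because the limit of > 15 uM in this assay, at which 3 of the 3 values shown sit, leaves the earlier step unreadable and gives no sign of a shift. Compound 4 is therefore expected to give 30 uM, most likely again only a limit, within an estimated range from 15 uM to 100 uM.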

Compound 4, half-maximal toxic concentration: 15 uM
The estimate for compound 4 lay 2.0-fold (0.30 log units) above the measured number; low and high end bracket the measured number.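

In this assay, putting 4-methyl-1,4-diazepan-1-yl in place of 4-methylpiperazin-1-yl on the sulfonyl sulfur gives a number no higher from compound 3 to compound 4 (the limit leaves the size open). Going by these compounds alone, compound 4, at 15 uM, holds the only true number in the set, so the change cannot be sized on either core: the limit of > 15 uM in this assay, at which 3 of the 4 values shown sit. Within the data shown here, this shows only that the change, carried to the core of compound 3, can end on a measured number at the edge of that limit; it does not show how large any shift is, or that the change acts alike on the two cores, and the earlier step from compound 1 to compound 2 cannot be read at all.

Still open, as far as these compounds go, is where compound 1, compound 2 and compound 3 really lie, since their values give no number. Also open, from the compounds shown here alone, is how either core would behave in this assay with a different group on the sulfonyl sulfur, such as a morpholine ring, an open-chain dimethylamino group or a carboxylic acid.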